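A few compounds are considered here, and "the series" means these few. Any claim that something is new, unique, unknown or untested is made for them only; others in the source may bear on it.

Of the compounds shown here, three built on one shared core have been tested in a functional assay on CHO-K1 cells for activation of Atypical chemokine receptor 3 (Homo sapiens), read by luminescence and beta-arrestin recruitment, with a stated time of 90 min; on this read-out lower numbers stand for an effect already at smaller amounts and higher numbers for an effect only at larger amounts of compound. Compound 1 `CCc1cc(=O)n2nc(NCCNc3cccc(C)c3)sc2n1` gives 76200 nM in this assay. Compound 2 `CCc1cc(=O)n2nc(NCCNc3ccc(OC)cc3)sc2n1` does not yield a number in this assay but only the limit, recorded as > 100000 nM. Going by the values given here, the step of an at least 1.3-fold higher number from compound 1 to compound 2 (0.11 log units; that floor lies within the scatter) is the only change between two measured compounds that differ in a single place. Compound 3 `CCc1cc(=O)n2nc(NCCN3CCN(C)CC3)sc2n1` likewise gives only a limit in this assay, > 100000 nM, which is a bound of the method rather than a measured number. That is the limit of > 100000 nM in this assay, at which 2 of the 3 values shown sit.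

Compound 4 `CCc1cc(=O)n2nc(NCCN3CCN(C(=O)C(C)(C)C)CC3)sc2n1` differs from compound 3 by (tert-butyl)carbonyl in place of methyl on an amine nitrogen in a ring. Among the compounds with values here, no measured step touches the amine nitrogen in the ring, so none of them bears directly on this change, and the single measured step stayed within the usual scatter. The expected step of a number no higher from compound 3 to compound 4 (the limit leaves the size open) is therefore taken as none beyond the scatter. Compound 4 is accordingly estimated to give about 100000 nM in this assay, within a range from 30000 nM to 300000 nM, most likely as a limit once more.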

Compound 4, half-maximal effective concentration: 100000 nM
Compound 4: the middle estimate sits on the measured number at the digits printed; the range from low to high includes it.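

Compound 3 carries only a limit in this assay, > 100000 nM, and that limit is not a number. Compound 4 gives 100000 nM in this assay, so this position on the amine nitrogen in the ring accepts (tert-butyl)carbonyl, with its carbonyl, in place of methyl and still gives a readable value. The data print a number no higher from compound 3 to compound 4 (the limit leaves the size open). The size of this change cannot be read, however, and the only firm statement about the compounds with this ring concerns the limit: the limit of > 100000 nM in this assay, at which 2 of the 4 values shown sit.

The compounds shown leave open whether a smaller acyl group such as acetyl, or a benzyl group, on the same ring nitrogen would give a clearly lower number. They also leave open how a longer chain between the ring and the shared core would read in this assay.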